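A few compounds are considered here, and "the series" means these few. Any claim that something is new, unique, unknown or untested is made for them only; others in the source may bear on it.

Compound 1 `CC(=O)N1N=C(c2ccc(OCc3cn(Cc4ccc([N+](=O)[O-])cc4)nn3)cc2)CC1c1ccccc1` is tested in a functional assay on A549 cells (Homo sapiens) for inhibition, read by sulforhodamine B assay, tested at 100 uM (on this read-out lower numbers stand for less inhibition of growth and higher numbers for more inhibition of growth at the one concentration tested), where compound 1 gives 80%. Among the measured compounds shown here, only one other compound has been measured alongside it, compound 2 `COc1cc(C2CC(c3ccc(OCc4cn(Cc5ccc([N+](=O)[O-])cc5)nn4)cc3)=NN2C(C)=O)ccc1Oc1cn(Cc2ccc([N+](=O)[O-])cc2)nn1`, which carries two of the nitrobenzyl triazole ether arms and a methoxy group; in this assay compound 2 gives 42%. Of the two numbers, compound 1 holds the higher one, and the gap to compound 2 lies beyond the usual scatter. Compound 3 `COc1ccc(C2CC(c3ccc(OCc4cn(Cc5ccc([N+](=O)[O-])cc5)nn4)cc3)=NN2C(C)=O)cc1` has not yet been measured. It differs from compound 1 in a single respect: methoxy in place of hydrogen on an aromatic carbon. For the measured compounds named here, no direct step between measured compounds covers this exact change, so the expected size rests on judgement alone. A modest decrease is expected for compound 3, with the step of a number 14 percentage points lower from compound 1 to compound 3 (beyond the scatter) thought likely to stay close to the scatter rather than far beyond it. On that basis compound 3 is estimated at 66% in this assay, with a range from 42% to 88%.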

Compound 3, percent growth inhibition at one concentration: 33%
Estimate against measurement, compound 3: 33 percentage points above; measured number below the stated range.
By their numbers in this assay, from the lowest: compounds 3 and 2 (each within the scatter of the next); then compound 1.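

In this assay, among the compounds shown here, the change from phenyl to 4-methoxyphenyl gives a number 47 percentage points lower from compound 1 to compound 3 (beyond the scatter), the first step that isolates a single position, and the step is large. The earlier compounds shown here differed in more than one place, whereas this pair shows that one methoxy on this aromatic carbon, para to a large group, is enough to remove much of the growth inhibition at the one concentration tested. Nothing available explains the size of this step.

The compounds shown leave open whether the drop is specific to methoxy or whether a hydroxyl, a chlorine or an amine on the same carbon would give a similar step. They also leave open how methoxy would behave on another carbon of this ring.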